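A few compounds are considered here, and "the series" means these few. Any claim that something is new, unique, unknown or untested is made for them only; others in the source may bear on it.

Measured so far:
compound 1, `COc1cccc(-c2cc(C(=O)Nc3ccc(Oc4ccnc5cc(OCCCN6CCCC6)c(OC)cc45)c(F)c3)c3ccccc3n2)c1`, 430 nM
compound 2, `COc1cc2c(Oc3ccc(NC(=O)c4cc(-c5ccc(C)cc5)nc5ccccc45)cc3F)ccnc2cc1OCCCN1CCCC1`, 300 nM
compound 3, `COc1cccc(-c2cc(C(=O)Nc3ccc(Oc4ccnc5cc(OCCCN6CCC(C)CC6)c(OC)cc45)c(F)c3)c3cc(F)ccc3n2)c1`, 730 nM

Compounds 1, 2 and 3 were tested in a functional assay on MKN-45 cells (Homo sapiens) for cytotoxicity, read by MTT assay, with a stated time of 72 h; on this read-out lower numbers stand for stronger inhibition and higher numbers for weaker inhibition. Compound 1 gives 430 nM in this assay, and compound 2, which carries 4-methylphenyl in place of 3-methoxyphenyl on an aromatic carbon, gives 300 nM. The step between them is a 1.4-fold lower number from compound 1 to compound 2 (0.16 log units; within the scatter). Compound 3 gives 730 nM in this assay, the highest of the three numbers; its gap to compound 1 lies within the scatter and its gap to compound 2 lies beyond it. The difference between the core of compound 3 and the core of compound 1 is not broken down here.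

Compound 4, `COc1cc2c(Oc3ccc(NC(=O)c4cc(-c5ccc(C)cc5)nc5ccc(F)cc45)cc3F)ccnc2cc1OCCCN1CCC(C)CC1`, has not yet been tested. It differs from compound 3 by 4-methylphenyl in place of 3-methoxyphenyl on an aromatic carbon, and the place line reads word for word as it does for the change from compound 1 to compound 2, so this is the same change made on the core of compound 3. Because the earlier step was a 1.4-fold lower number from compound 1 to compound 2 (0.16 log units; within the scatter), a step of similar size is expected here: a 1.4-fold lower number from compound 3 to compound 4 (0.15 log units; within the scatter). This rests on a single earlier instance of the change and on the value of compound 3, 730 nM, so the expectation is loose. Compound 4 is estimated at 520 nM in this assay, with a range expected from 250 nM to 1100 nM.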

Compound 4, half-maximal inhibitory concentration: 260 nM
Compound 4: the middle estimate sits 2.0-fold (0.30 log units) above what was measured, within the range that was stated.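

In this assay, 4-methylphenyl in place of 3-methoxyphenyl on the second core gives a 2.8-fold lower number from compound 3 to compound 4 (0.45 log units; beyond the scatter). Among these compounds, only this step lies beyond the scatter, yet it cannot be told apart from the earlier step, so the change can be said to have carried from one core to the other without a measurable difference in size: the same change on two cores in this assay, a 1.4-fold lower number (0.16 log units; within the scatter) from compound 1 to compound 2 and a 2.8-fold lower number (0.45 log units; beyond the scatter) from compound 3 to compound 4, 2.0-fold (0.29 log units) apart, within the scatter of two such steps This does not show that the change has the same size on every core, since there are only two instances, one of which lies within the scatter, and it does not show whether the differences between the two cores have any bearing on the step.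

The change alters both the group and where its substituent sits on the phenyl ring, so the compounds shown leave open which of the two matters, a question that 4-methoxyphenyl or 3-methylphenyl on the same aromatic carbon would address. They also leave open how the step would behave with another group on that carbon, such as 4-chlorophenyl, or with a morpholine at the end of the propoxy chain.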